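Benzylamino in place of methylamino: clearance outlook

The compounds below may be only part of what the source reports. "The series", "measured", "known", "first", "only" and "open" are said of these compounds alone.

Measured in an ADME assay (liver) for metabolic stability, with Liver microsome (Rattus norvegicus) as the target, using microsomes and NADPH, with a stated time of 30 min, at 37 degrees C, tested at 1 uM (a higher number here means faster removal of the compound, a lower number slower removal), so far:
- Compound 1 `COc1cc(C(O)(C(F)(F)F)C(F)(F)F)cnc1-c1ccc(S(=O)(=O)c2ccc(N)nc2)cc1` gives < 14 mL.min-1.g-1 as a limit of the assay
- Compound 2 `COCC#Cc1cc(C(O)(C(F)(F)F)C(F)(F)F)cnc1-c1ccc(S(=O)(=O)c2ccc(N)nc2)cc1` gives > 399 mL.min-1.g-1 as a limit of the assay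
- Compound 3 `CNc1nc(S(=O)(=O)c2ccc(N)nc2)ccc1-c1ccc(C(C)(O)C(F)(F)F)cn1` gives 21 mL.min-1.g-1 as a measured number

Compound 3 is the only one of the three with a true number (21 mL.min-1.g-1). The other two values are limits. Compound 4 `CC(O)(c1ccc(-c2ccc(S(=O)(=O)c3ccc(N)nc3)nc2NCc2ccccc2)nc1)C(F)(F)F` turns the methylamino of compound 3 into benzylamino (phenyl in place of hydrogen on a saturated chain carbon bound to a nitrogen on an aromatic ring). It adds phenyl in place of hydrogen on a saturated chain carbon bound to a nitrogen on an aromatic ring.

Within the data shown here, only one measured step is available. It is an at least 28-fold higher number from compound 1 to compound 2 (1.45 log units; beyond the scatter) when 3-methoxyprop-1-yn-1-yl replaces methoxy on an aromatic carbon. That step is large, but it concerns another group on the core of compound 1 and ends on a limit, so it guides direction only loosely. Faster removal is expected for compound 4 on the direction of an at least 28-fold higher number from compound 1 to compound 2 (1.45 log units; beyond the scatter) alone, by a smaller step. The estimated step is a 3.3-fold higher number from compound 3 to compound 4 (0.52 log units; beyond the scatter) in size. Compound 4 is estimated at 70 mL.min-1.g-1 in this assay with 25 mL.min-1.g-1 to 250 mL.min-1.g-1 as its expected range.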

Compound 4, intrinsic clearance in microsomes: 114 mL.min-1.g-1
Compound 4: the middle estimate sits 1.6-fold (0.21 log units) below what was measured; low and high end bracket the measured number.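

In this assay, among these compounds, the change from methylamino to benzylamino gives a 5.4-fold higher number from compound 3 to compound 4 (0.73 log units; beyond the scatter) and this is the only step in the set read between two true numbers, not against a limit of the assay. It shows that phenyl in place of hydrogen on a saturated chain carbon bound to a nitrogen on an aromatic ring moves the read-out towards faster removal, and it gives that move a size, which the step on the core of compound 1 could not do. Nothing measured here accounts for this shift.

The compounds shown leave open whether the higher number needs the phenyl itself or would also come with a plain alkyl chain at this place, such as ethylamino or butylamino. They also leave open how a carboxylic acid or an amine on the phenyl of compound 4 would change the read-out.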